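The compounds below may be only part of what the source reports. "The series", "measured", "known", "first", "only" and "open" are said of these compounds alone.

Measured so far:
compound 1, `CC(C)CC(=O)[C@@H]1O[C@@]12C(=O)C=C(Cc1ccccc1)NC2=O` — in an ADME assay on HEK293 cells (Homo sapiens) for cytotoxicity, read by WST assay, with a stated time of 48 h (on this read-out higher numbers stand for weaker inhibition and lower numbers for stronger inhibition), compound 1 gives > 50000 nM
compound 2, `CC1=CC(=O)[C@]2(O[C@@H]2C(=O)CC(C)C)C(=O)N1` — in this assay compound 2 gives "not determined" (no result reported)

The value of compound 1 in this assay is a limit of the assay, not a number; it stands at the limit of > 50000 nM in this assay, at which 1 of the 2 values shown sits. For compound 2 there is no result in this assay. Compound 2 therefore holds no place on the numbers shown; the single value in the set is the limit of compound 1, and nothing can be said of any gap between the two.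

Compound 3, `CC1=CC(=O)C2(OC2C(=O)CC(C)C)C(=O)N1`, is to be measured in this assay. Its difference from compound 2: the two compounds have the same atoms and bonds; at least one stereo element is drawn with a configuration in one of them and without one in the other: 2 of 2 stereo elements differ; a stereocentre at a saturated ring carbon is drawn S in compound 2 and without a configuration in compound 3; a stereocentre at a saturated ring carbon is drawn S in compound 2 and without a configuration in compound 3. Going by the values given here, no step between measured compounds is known, so in this assay the step from compound 2 to compound 3 is expected to be none beyond the scatter, in no particular direction.

Compound 3 in this assay is estimated at 50000 nM, with a range of 20000 nM to 100000 nM. A limit rather than a number is the more likely outcome for compound 3, because the only result in the set, that of compound 1, is itself the limit (the limit of > 50000 nM in this assay, at which 1 of the 2 values shown sits).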

Compound 3, half-maximal inhibitory concentration: 35900 nM
Compound 3: middle estimate off by 1.4-fold (0.14 log units), on the high side; the range from low to high includes it.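

Going by these compounds alone, compound 2 has no numerical result in this assay, so no step from compound 2 to compound 3 can be read. What the compounds shown leave open is whether the value in this assay depends on the single difference within this pair: the fact that one of compounds 2 and 3 is drawn with a defined configuration and the other without, at the place where they differ.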